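Three Measured Analogues and One Awaiting Measurement

This account rests on a few compounds, and the source may have more. Where it says the series, first, only, none or still open, it means among the compounds named here.

Compound 1 `Cc1ccc(CS/C(=C/c2ccc(O)cc2)C(=O)c2ccc(Cl)cc2)cc1` gives 10000 nM. Compound 2 `COc1ccccc1/C=C(\C(=O)c1ccc(Cl)cc1)S(=O)(=O)Cc1ccc(Cl)c(Cl)c1` gives 1000 nM. Compound 3 `COc1ccccc1/C=C(/SCc1ccc(C)cc1)C(=O)c1ccc(Cl)cc1` gives 10000 nM.

These numbers come from a functional assay on DU-145 cells (Homo sapiens) for inhibition, read by trypan blue exclusion, with a stated time of 96 h; on this read-out lower numbers stand for stronger inhibition of growth and higher numbers for weaker inhibition of growth. Compound 2 stands lowest, with both compound 1 and compound 3 beyond the scatter from it. How the core of compound 2 differs from that of compound 3 is not broken down here. From compound 3 to compound 1 the change is 4-hydroxyphenyl in place of 2-methoxyphenyl on a double-bonded chain carbon bound to a double-bonded chain carbon, and it gave no change at the digits printed from compound 3 to compound 1 (within the scatter). Compound 4 `O=C(/C(=C\c1ccc(O)cc1)S(=O)(=O)Cc1ccc(Cl)c(Cl)c1)c1ccc(Cl)cc1` is not yet measured; it differs from compound 2 by 4-hydroxyphenyl in place of 2-methoxyphenyl on a double-bonded chain carbon bound to a double-bonded chain carbon, the same change seen between compound 3 and compound 1. Since that earlier step was flat, compound 4 is expected to sit close to compound 2, a step of no change at the digits printed from compound 2 to compound 4 (within the scatter). Compound 4 is estimated at 1000 nM, between 300 nM and 3500 nM.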

Compound 4, concentration for 50% growth inhibition: 10000 nM
The estimate for compound 4 lay 10-fold (1.00 log units) below the measured number; the whole stated range lies below it.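

In this assay, placing 4-hydroxyphenyl where 2-methoxyphenyl stood gave a 10-fold higher number from compound 2 to compound 4 (1.00 log units; beyond the scatter). The change therefore did not carry over with the same result from one core to the other: the same change on two cores in this assay, no change at the digits printed (within the scatter) from compound 3 to compound 1 and a 10-fold higher number (1.00 log units; beyond the scatter) from compound 2 to compound 4, 10-fold (1.00 log units) apart, beyond the scatter of two such steps. This shows that, in these two pairs, the result of the change depended on the core, but it does not show which difference between the core of compound 2 and the core of compound 3 is responsible, and two pairs set no rule for the series.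

The compounds shown leave open how the change behaves on cores that differ from these in only one place. They also leave open what an amine or a carboxylic acid would do in place of the 4-hydroxyphenyl.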